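The source may hold more compounds than are shown below. What is called first, only, known or untested is meant among the compounds shown, and "the series" means these compounds.

Of the compounds shown here, three sharing one core have been measured for their ability to switch on G-protein coupled receptor 52 in cells. Compound 1 `Cc1nc(Cc2cccc(C(F)(F)F)c2)sc1-c1ccc(C(N)=O)cc1` gives 220 nM in a functional assay on cells for agonist activity at G-protein coupled receptor 52 (Homo sapiens), read by AlphaScreen and cAMP accumulation, with a stated time of 30 min (a lower number here means that less compound is needed, a higher number that more compound is needed for the effect), the second highest of the three numbers. Compound 2 `Cc1cc(-c2sc(Cc3cccc(C(F)(F)F)c3)nc2C)ccc1C(N)=O` gives 73 nM, and compound 3 `Cc1nc(Cc2cccc(C(F)(F)F)c2)sc1-c1ccc(C(N)=O)c(C(C)C)c1` gives 370 nM. Compound 4 `COc1cc(-c2sc(Cc3cccc(C(F)(F)F)c3)nc2C)ccc1C(N)=O` is not yet measured; it differs from compound 1 by methoxy in place of hydrogen on an aromatic carbon. Within the data shown here, two measured steps concern the same position. Adding a methyl there gave a 3.0-fold lower number from compound 1 to compound 2 (0.48 log units; beyond the scatter), whereas adding an isopropyl gave a 1.7-fold higher number from compound 1 to compound 3 (0.23 log units; within the scatter). Methoxy, with 2 heavy atoms, sits between those two groups in bulk, and the two steps point in different directions, so a small improvement or no change beyond the scatter is the most that can reasonably be expected. Compound 4 is therefore estimated at 150 nM, with a likely range from 50 nM to 450 nM. The step this estimate implies, a 1.5-fold lower number from compound 1 to compound 4 (0.17 log units; within the scatter), is expected to be modest at most.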

Compound 4, half-maximal effective concentration: 170 nM
Compound 4: middle estimate off by 1.1-fold (0.05 log units), on the low side; the range from low to high includes it.
By their numbers in this assay, from the lowest: compound 2; then compounds 4, 1 and 3 (each within the scatter of the next, the first and the last beyond it).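

At this aromatic carbon, ortho to a carbamoyl group, methoxy in place of hydrogen leaves the number within the scatter (a 1.3-fold lower number from compound 1 to compound 4 (0.11 log units; within the scatter)), so the gain seen with methyl does not extend to every small group placed there. Methyl and methoxy are now seen to differ (a 2.3-fold higher number from compound 2 to compound 4 (0.37 log units; beyond the scatter)), and so do isopropyl and methoxy (a 2.2-fold lower number from compound 3 to compound 4 (0.34 log units; beyond the scatter)), even though hydrogen lies within the scatter of both methoxy and isopropyl. No measurement at hand explains why these groups differ.

On these data alone, whether a chlorine atom, an ethyl group or an amine at this carbon would match methyl remains open. As far as these compounds go, it is also open whether methyl would give a similar step on another carbon of this six-membered aromatic ring.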